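The compounds below may be only part of what the source reports. "The series", "measured", "known", "first", "only" and "open" are said of these compounds alone.

Measured so far:
compound 1, `CCCCCCCCCCCCCC[C@H](OCOC)[C@H](CO)NC(=O)OC(C)(C)C`; in a functional assay on DLD-1 cells (Homo sapiens) for antiproliferative activity, read by sulforhodamine B assay, with a stated time of 48 h, tested at 10 uM (on this read-out lower numbers stand for less inhibition and higher numbers for more inhibition at the one concentration tested (going by the name of the read-out)), compound 1 gives 54.8%
compound 2, `CCCCCCCCCCCCCC[C@H](OCOC)[C@H](CN(CC)CC)NC(=O)OC(C)(C)C`; in this assay compound 2 gives 46.2%

Going by the values given here, compound 2 stands lowest of the two numbers, but its only neighbour is compound 1, and the step of a number 8.6 percentage points lower from compound 1 to compound 2 (within the scatter) lies within the scatter, so the two readings cannot be ranked.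

Compound 3, `CCCCCCCCCCCCCC[C@H](OCOC)[C@H](CN(C(C)C)C(C)C)NC(=O)OC(C)(C)C`, is not yet measured. Its difference from compound 2: diisopropylamino in place of diethylamino on a saturated chain carbon, two bonds along the chain from an amide-type nitrogen

Among the compounds with values here, the only step that bears on this change is the one at the same place, a number 8.6 percentage points lower from compound 1 to compound 2 (within the scatter), which was within the scatter. Within the data shown here, no step between two amino groups at this carbon has been measured. On that basis a step of a number 0.2 percentage points lower from compound 2 to compound 3 (within the scatter) is expected, that is, none beyond the scatter in either direction. Compound 3 is estimated at 46%, within a range from 30% to 62%.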

Compound 3, a percentage reported as inhibition, at one concentration (the size of the read-out at that concentration, not a potency): 53.9%
Beside the measured number, compound 3's estimate is 7.9 percentage points below it; low and high end bracket the measured number.
By their numbers in this assay, from the lowest: compounds 2, 3 and 1 (each within the scatter of the next).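

In this assay, going by these compounds alone, the first step between two amino groups at this position can now be read: diisopropylamino in place of diethylamino on a saturated chain carbon, two bonds along the chain from an amide-type nitrogen, gives a number 7.7 percentage points higher from compound 2 to compound 3 (within the scatter), so the two amines cannot be told apart. Diisopropylamino in place of hydroxy at the same carbon gives a number 0.9 percentage points lower from compound 1 to compound 3 (within the scatter), so this second amine, like diethylamino, cannot be told apart from the hydroxy group of compound 1. No supporting measurement is available to account for these readings.

Going by these compounds, it remains open whether a primary amine, a piperidine ring or a carboxylic acid at this carbon would give a reading beyond the scatter of these three compounds. On these data alone, the effect of a shorter chain in place of the long alkyl chain also remains open.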